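Moving the gem-dimethyl pair around the pyrrolidine ring

The source may hold more compounds than are shown below. What is called first, only, known or untested is meant among the compounds shown, and "the series" means these compounds.

Compound 2 `COc1cc(C(=O)N2CCCC2(C)C)cc2nc(NCc3cccc(Cl)c3)oc12` holds the lowest of the two numbers measured in an assay on isolated protein for inhibition of thyroid hormone receptor beta (Homo sapiens), read by fluorescence, with a stated time of 30 min (a lower number here means a stronger inhibitor, a higher number a weaker inhibitor), where compound 2 gives 47 nM. Going by the values given here, its nearest neighbour is compound 1 `COc1cc(C(=O)N2CCCC2)cc2nc(NCc3cccc(Cl)c3)oc12`, which in this assay gives 180 nM; the step of a 3.8-fold lower number from compound 1 to compound 2 (0.58 log units; beyond the scatter) is the only measured change on the amide ring and it lies beyond the scatter.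

Compound 3 `COc1cc(C(=O)N2CCC(C)(C)C2)cc2nc(NCc3cccc(Cl)c3)oc12` keeps every atom of compound 2 but joins them differently: 3,3-dimethylpyrrolidin-1-yl in place of 2,2-dimethylpyrrolidin-1-yl on a carbonyl carbon. Among the compounds with values here, no measured pair describes a shift of the two methyl groups from one ring carbon to another; the step from compound 1 to compound 2 only shows that adding both methyl groups to the ring was worth a modest gain. Whether that gain survives when the methyl groups sit elsewhere is not known from these two compounds, so the expected step of a 1.9-fold higher number from compound 2 to compound 3 (0.28 log units; within the scatter) is taken as small, most likely a partial give-back toward compound 1 rather than a further gain. The estimate for compound 3 in this assay is therefore 90 nM, with a range from 35 nM to 230 nM.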

Compound 3, half-maximal inhibitory concentration: 40 nM
For compound 3 the middle estimate is 2.3-fold (0.35 log units) above the measured one; the measured number falls inside the stated range.
By their numbers in this assay, from the lowest: compounds 3 and 2 (each within the scatter of the next); then compound 1.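

In this assay, moving the gem-dimethyl pair gives a 1.2-fold lower number from compound 2 to compound 3 (0.07 log units; within the scatter), a step within the scatter, so the 2,2-dimethylpyrrolidin-1-yl and 3,3-dimethylpyrrolidin-1-yl amides cannot be told apart in this assay. The new ring also stands clear of the plain pyrrolidin-1-yl amide, with a 4.5-fold lower number from compound 1 to compound 3 (0.65 log units; beyond the scatter), a step beyond the scatter, so the modest gain first seen with compound 2 is not confined to one placement of the pair and appears at both ring carbons shown. Nothing available explains either step or the likeness of compound 2 and compound 3.

What the compounds shown leave open is whether both methyl groups are needed, since a single methyl group on the pyrrolidine ring does not appear among them, and whether the gain would hold with a larger group such as a spiro-fused cyclopropane or with a hydroxyl or an amine on the same ring. Also open, on these data alone, is whether the five-membered ring itself matters, which a piperidin-1-yl or morpholin-4-yl amide on the same carbonyl carbon would address.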